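The source may hold more compounds than are shown below. What is called first, only, known or untested is meant among the compounds shown, and "the series" means these compounds.

Working notes on the series. The shared core is carried unchanged through the set; compound 1 `CC1(c2ccccc2)CC(=O)N(CC(=O)N2CCN(c3ccccc3F)CC2)C1=O`, compound 2 `CC1(c2ccccc2)CC(=O)N(CC(=O)N2CCN(c3cccc(Cl)c3)CC2)C1=O` and compound 3 `CC1(c2ccccc2)CC(=O)N(CC(=O)N2CCN(c3ccc(Cl)c(Cl)c3)CC2)C1=O` differ only in the aromatic group on the amine nitrogen of the six-membered non-aromatic ring. In a functional assay on the whole organism (strain CD-1) with Mus musculus as the target, with a stated time of 2 h (on this read-out lower numbers stand for an effect already at smaller amounts and higher numbers for an effect only at larger amounts of compound), compound 1 gives 300 mg/kg, the only numerical result so far. In this assay compound 2 is reported as "not active" (no number reported), with no dose given. Compound 3 is likewise reported as "not active" (no number reported) in this assay. Compound 2 therefore stands without a number: nothing in this assay separates it from compound 3, and the result of compound 1 is the only anchor for where a measurable dose in this set lies.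

Compound 4 `CC1(c2ccccc2)CC(=O)N(CC(=O)N2CCN(c3ncccn3)CC2)C1=O` is the next member to be tested. It differs from compound 2 by the change (pyrimidin-2-yl in place of 3-chlorophenyl on an amine nitrogen in a ring).

For the measured compounds named here, no step between measured compounds is available for this change, and compound 2 itself has no number, so no size or direction of step can be set against it; what can be said is that a numerical result for compound 4 would already be a move relative to compound 2, and that the only measured dose in the set, that of compound 1, sits high. Compound 4 is expected to give about 300 mg/kg in this assay, within a range from 100 mg/kg to 1000 mg/kg, with a substantial chance that, like compound 2, only a limit and no number is reported.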

Compound 4, minimum effective dose: 100 mg/kg
For compound 4 the middle estimate is 3.0-fold (0.48 log units) above the measured one; the range from low to high includes it.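

In this assay, for the compounds shown here, the amine nitrogen in a ring tolerates a six-membered aromatic ring with 2 hetero atoms and still gives a numerical dose: pyrimidin-2-yl in place of 2-fluorophenyl gives a 3.0-fold lower number from compound 1 to compound 4 (0.48 log units; beyond the scatter), the first step that can be read, modest in size but beyond the usual scatter. Going by these compounds alone, the steps from compound 2 and from compound 3 to compound 4 cannot be read, as neither of those two compounds has a number; the reports show only that compound 4 has a dose with a number while they are recorded as not active. No measurement at hand explains the difference between the aromatic groups at this position.

The compounds shown do not tell whether this result belongs specifically to pyrimidin-2-yl or extends to other aromatic rings carrying ring nitrogen, such as pyridin-2-yl, or to an unsubstituted phenyl group at the same place. They also leave open whether the step would carry over to a core in which an ethyl group replaces the methyl group.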